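Pent-1-en-1-yl in place of vinyl: compound 2 to compound 3

The source may hold more compounds than are shown below. What is called first, only, known or untested is meant among the compounds shown, and "the series" means these compounds.

For the measured compounds named here, in a functional assay on MCF7 cells (Homo sapiens) for antiproliferative activity, read by MTT assay, with a stated time of 72 h (a lower number here means a stronger inhibitor, a higher number a weaker inhibitor), compound 2 `C=CC(=O)Nc1cccc(Oc2nc(Nc3ccc(OC)nc3)nc3c2CSCC3)c1` gives 17200 nM and compound 1 `CCC/C=C/C(=O)Nc1cccc(Oc2nc(Nc3cccc(C#N)c3)nc3c2CSCC3)c1` gives 15300 nM as its value, so the only two numbers in hand lie within the scatter of each other. Compound 3 `CCC/C=C/C(=O)Nc1cccc(Oc2nc(Nc3ccc(OC)nc3)nc3c2CSCC3)c1` is not yet measured and differs from compound 2 by pent-1-en-1-yl in place of vinyl on a carbonyl carbon in one place: pent-1-en-1-yl in place of vinyl on a carbonyl carbon. Going by the values given here, no measured pair isolates this change. Compound 1 already carries pent-1-en-1-yl on a carbonyl carbon and stands at 15300 nM in the same range as compound 2, which is the only hint available. In this assay the expected 1.1-fold lower number from compound 2 to compound 3 (0.06 log units; within the scatter) stays within the scatter. Compound 3 is estimated at 15000 nM with 6500 nM to 32000 nM as the expected range.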

Compound 3, half-maximal inhibitory concentration: 26800 nM
Compound 3: middle estimate off by 1.8-fold (0.25 log units), on the low side; low and high end bracket the measured number.
By their numbers in this assay, from the lowest: compounds 1, 2 and 3 (each within the scatter of the next).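

In this assay, for the compounds shown here, the first pair that isolates the group on the carbonyl carbon reads a 1.6-fold higher number from compound 2 to compound 3 (0.19 log units; within the scatter) and so stays within the scatter: on this core, pent-1-en-1-yl in place of vinyl gives no readable change. Going by these compounds alone, the first pair that isolates the group on a nitrogen on an aromatic ring reads a 1.8-fold higher number from compound 1 to compound 3 (0.24 log units; within the scatter) and is also within the scatter, so 6-methoxypyridin-3-yl in place of 3-cyanophenyl is not separated from 3-cyanophenyl with pent-1-en-1-yl on the carbonyl carbon. No supporting measurement is available to explain either step.

Going by these compounds, whether a longer chain or an amine-bearing chain on the carbonyl carbon would move the number beyond the scatter remains open. Also open, on these data alone, is whether any other group on that nitrogen, such as a carboxylic acid-bearing phenyl, would separate from these values in this assay at all.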